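The compounds below may be only part of what the source reports. "The series", "measured", "known", "first", "only" and "open" are said of these compounds alone.

Series measured in a functional assay on HepG2 cells (Homo sapiens) for cytotoxicity, read by spectrophotometry, with a stated time of 72 h; a higher number here means a weaker inhibitor, a lower number a stronger inhibitor:

- Compound 1 `COc1ccc(-c2cccc(=O)n2-c2cc(OC)c(OC)c(OC)c2)cc1`: < 10 nM, a limit of the assay
- Compound 2 `COc1cc(-n2c(-c3ccc([N+](=O)[O-])cc3)cccc2=O)cc(OC)c1OC`: < 10 nM, a limit of the assay
- Compound 3 `COc1cc(-n2c(-c3cccc(F)c3)cccc2=O)cc(OC)c1OC`: 159 nM

Compound 2 has no exact number and sits on (the limit of < 10 nM in this assay, at which 2 of the 3 values shown sit). Compound 4 `COc1cc(-n2c(-c3ccc(OC(F)(F)F)cc3)cccc2=O)cc(OC)c1OC` is the next case: trifluoromethoxy in place of nitro on an aromatic carbon. This places trifluoromethoxy in place of nitro on an aromatic carbon, para to a large group.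

The closest measured change at this aromatic carbon is a step that the two limits leave unreadable from compound 1 to compound 2, so it gives no size to carry over. Replacing the whole aryl group counts for more, with an at least 15-fold higher number from compound 1 to compound 3 (1.20 log units; beyond the scatter) and an at least 15-fold higher number from compound 2 to compound 3 (1.20 log units; beyond the scatter), both beyond the scatter. These two steps show that this assay can respond strongly to the aryl group, but compound 3 differs from compound 4 in both the group and its position. Among the compounds with values here, only three compounds support this reading, and the 4-methoxyphenyl and 4-nitrophenyl compounds both remain at the limit.

Compound 4 keeps a 4-substituted phenyl, so a modest move towards a higher number is expected, smaller than the steps to compound 3, and a result at the limit remains quite possible. The estimated change is an at least 1.5-fold higher number from compound 2 to compound 4 (0.17 log units; that floor lies within the scatter). For compound 4 the expected value is 15 nM. The estimated range for compound 4 runs from 3 nM to 100 nM.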

Compound 4, half-maximal inhibitory concentration: 1960 nM
The estimate for compound 4 lay 130-fold (2.12 log units) below the measured number; the measured number lies above the stated range.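

In this assay, the aromatic carbon para to a large group proves far less permissive than compound 1 and compound 2 suggested, since trifluoromethoxy in place of nitro gives an at least 190-fold higher number from compound 2 to compound 4 (2.29 log units; beyond the scatter); the earlier pair offered no readable step at this carbon. The oxygen-linked substituent also matters: trifluoromethyl in place of methyl on that oxygen gives an at least 190-fold higher number from compound 1 to compound 4 (2.29 log units; beyond the scatter), so a change confined to the end of the group is enough to produce a large step, and keeping a 4-substituted phenyl does not by itself keep a compound at the limit, with compound 4 going against compound 1 and compound 2. Both steps are floors rather than full sizes because each begins at an assay limit: the limit of < 10 nM in this assay, at which 2 of the 4 values shown sit.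

The compounds shown leave open whether the higher number follows the three fluorines, the oxygen-linked trifluoromethyl unit as a whole, or some other feature of this substituent. An ethoxy chain, a directly attached trifluoromethyl, an amine or a carboxylic acid at the same carbon would show how narrow the range of accepted groups is, and exact values for compound 1 and compound 2 are still needed to size these steps.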